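Replacing the allyl(methyl)amide of compound 2 with an anilide

The compounds below may be only part of what the source reports. "The series", "measured", "known", "first", "only" and "open" are said of these compounds alone.

Compound 2 `C=CCN(C)C(=O)c1ccc(C(CC)(CC)c2ccc(OCCC(O)(CC)CC)c(C)c2)n1CC` is one of two measured members of a series built on a shared core. In an assay on cells for agonist activity at vitamin D3 receptor (Homo sapiens), with a stated time of 96 h (on this read-out lower numbers stand for an effect already at smaller amounts and higher numbers for an effect only at larger amounts of compound), compound 2 reaches only the limit of the assay, > 10000 nM, and not a number. Its partner compound 1 `CCn1c(C(=O)NCCN)ccc1C(CC)(CC)c1ccc(OCCC(O)(CC)CC)c(C)c1` gives 156 nM in this assay. Going by the values given here, the one measured step, an at least 64-fold higher number from compound 1 to compound 2 (1.80 log units; beyond the scatter), is anchored by the limit of > 10000 nM in this assay, at which 1 of the 2 values shown sits, so its true size is not known. Compound 3 `CCn1c(C(=O)Nc2cccc(C(F)(F)F)c2)ccc1C(CC)(CC)c1ccc(OCCC(O)(CC)CC)c(C)c1` differs from compound 2 by (3-(trifluoromethyl)phenyl)amino in place of allyl(methyl)amino on a carbonyl carbon. Among the compounds with values here, because the only comparison, an at least 64-fold higher number from compound 1 to compound 2 (1.80 log units; beyond the scatter), shows that changing the amide substituent can move this assay by a large amount, and because compound 1, which also carries an amide hydrogen, gives 156 nM, a gain is expected for compound 3. For compound 3 a step of an at least 6.6-fold lower number from compound 2 to compound 3 (0.82 log units; beyond the scatter) in this assay is estimated. Compound 3 is expected to show about 1500 nM, within a range from 150 nM to 10000 nM.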

Compound 3, half-maximal effective concentration: 5900 nM
Compound 3: middle estimate off by 3.9-fold (0.59 log units), on the low side; the range from low to high includes it.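

In this assay, keeping the amide hydrogen does not by itself hold the level of compound 1: with 3-(trifluoromethyl)phenyl in place of 2-aminoethyl on the amide-type nitrogen, the result is a 38-fold higher number from compound 1 to compound 3 (1.58 log units; beyond the scatter). Among the three amides, compound 1 with its 2-aminoethyl group therefore stands apart, as its steps to both other compounds lie beyond the scatter. The change from the allyl(methyl)amide is harder to size, with an at least 1.6-fold lower number from compound 2 to compound 3 (0.22 log units; that floor lies within the scatter), and the true step may be larger: the limit of > 10000 nM in this assay, at which 1 of the 3 values shown sits.

From the compounds shown here alone, whether the primary amine of compound 1 is what sets it apart remains open, and a 2-hydroxyethyl group or a longer aminoalkyl chain on the same nitrogen would test this. Also open, going by these compounds, is what a plain phenyl ring, without the trifluoromethyl group, would give.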